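This account rests on a few compounds, and the source may have more. Where it says the series, first, only, none or still open, it means among the compounds named here.

Compound 1: `OC[C@H]1O[C@H](Oc2ccc(-c3ccc(Cl)cc3Cl)cc2Cl)[C@@H](O)[C@@H](O)[C@@H]1O` — "not determined" (no result reported)
Compound 2: `N#Cc1ccc(-c2ccc(O[C@H]3O[C@H](CO)[C@@H](O)[C@H](O)[C@@H]3O)c(Cl)c2)cc1` — 2.1
Compound 3: `OC[C@H]1O[C@H](Oc2ccc(-c3ccc(Cl)c(Cl)c3)cc2Cl)[C@@H](O)[C@@H](O)[C@@H]1O` — "not determined" (no result reported)

Three compounds share a sugar attached through oxygen to a chlorinated biphenyl core and have been looked at in a physicochemical assay for lipophilicity, read by LC-MS, measured as octanol-water partition, with a stated time of 2 h, at pH 7.4, tested at 1 uM; on this read-out higher numbers stand for higher lipophilicity and lower numbers for lower lipophilicity. Only compound 2 carries a number: in this assay compound 2 gives 2.1. Compound 1 and compound 3 have no result in this assay, so compound 1 stands without a number, and nothing can be said about how it compares with compound 2 or compound 3.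

The next compound, compound 4, has the structure `O=[N+]([O-])c1cccc(-c2ccc(O[C@H]3O[C@H](CO)[C@@H](O)[C@H](O)[C@@H]3O)c(Cl)c2)c1` and has not yet been measured in this assay. It is reached from compound 1 by a single replacement at the far end of the biphenyl: 3-nitrophenyl in place of 2,4-dichlorophenyl on an aromatic carbon. Going by the values given here, since compound 1 has no number, the size of this step in this assay cannot be set against a starting value; no step between measured compounds is available either.

Among the compounds with values here, compound 4 is therefore expected to land close to compound 2, the one measured compound that carries a single small group rather than two chlorines on the outer ring, because compound 2 gives 2.1. On that basis compound 4 is estimated at 2.3 in this assay, with a likely range from 1.8 to 2.8.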

Compound 4, distribution coefficient: 2.4
The estimate for compound 4 lay 0.10 log units below the measured number, and the stated range covers the measured number.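

The outer ring now has its first comparison with a number on both sides: with 3-nitrophenyl in place of 4-cyanophenyl on an aromatic carbon, this assay shows a number 0.30 log units higher from compound 2 to compound 4 (within the scatter). At this position, then, these two outer rings cannot be told apart on this read-out, even though the swap changes both the group on the ring and where it sits, and the pair cannot show which of those two differences matters. Nothing measured here offers an explanation for this result.

The steps that involve compound 1 or compound 3 cannot be read, so the compounds shown leave open how 2,4-dichlorophenyl or the other dichlorinated outer ring compares with the rings of compound 2 and compound 4. They also leave open whether an outer ring carrying an amine or a carboxylic acid would read apart from these two, or whether the nitro and nitrile groups would read alike at other places on the ring.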